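Adding a Methyl Group to Compound 1

This account rests on a few compounds, and the source may have more. Where it says the series, first, only, none or still open, it means among the compounds named here.

Compound 1 `NS(=O)(=O)c1ccc(N2N=C(c3ccc(OCc4ccccc4)cc3)CC2c2ccccc2)cc1` was examined in an ADME assay on Vero 76 cells (Chlorocebus sabaeus) for cytotoxicity, read by MTT assay, with a stated time of 96 h; a lower number here means that less compound is tolerated, a higher number that more compound is tolerated. In this assay compound 1 gives > 100000 nM, which is a limit of the assay and not a measured number. Compound 2 `Cc1cccc(C2CC(c3ccc(Oc4ccccc4)cc3)=NN2c2ccc(S(N)(=O)=O)cc2)c1` gives 81000 nM in this assay. Compound 1 thus stands at the limit of > 100000 nM in this assay, at which 1 of the 2 values shown sits, and where it truly lies above that point cannot be said from the data.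

Compound 3 `Cc1cccc(C2CC(c3ccc(OCc4ccccc4)cc3)=NN2c2ccc(S(N)(=O)=O)cc2)c1` has not yet been measured in this assay. It differs from compound 1 by methyl in place of hydrogen on an aromatic carbon. Among the compounds with values here, no two measured compounds in this set differ in a single place, so no measured step is available to guide the expectation. Given that compound 1 sits at a limit, the step of a number no higher from compound 1 to compound 3 (the limit leaves the size open) is expected to be small, within the usual scatter, and a limit may again be reported. Compound 3 is therefore estimated at 100000 nM, with a range from 50000 nM to 200000 nM.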

Compound 3, half-maximal cytotoxic concentration: 100000 nM
The estimate for compound 3 equals the measured number at the digits printed; low and high end bracket the measured number.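

In this assay, benzyl in place of phenyl on an oxygen on an aromatic ring, with the 3-methylphenyl group present on both sides of the step, gives a 1.2-fold higher number from compound 2 to compound 3 (0.09 log units; within the scatter). Within the data shown here, this is the first single change that can be read in this set, and it does not separate the two compounds. Methyl in place of hydrogen on an aromatic carbon gives a number no higher from compound 1 to compound 3 (the limit leaves the size open). The size of this step cannot be read, because compound 1 stands at a limit of the assay and not at a measured number: the limit of > 100000 nM in this assay, at which 1 of the 3 values shown sits.

Going by these compounds, how far compound 1 lies past that limit therefore stays unknown, and so does the size of the methyl step. Also open, on these data alone, is what a different group on that ring, such as an amine, a carboxylic acid or a longer chain, would give in this assay.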